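The source may report more compounds than this note shows. Statements on the series, on what has been measured and on what is new or still open speak of the compounds shown alone.

Measured in a functional assay on CEM-DNR-bulk cells (Homo sapiens), read by MTT assay, with a stated time of 72 h; on this read-out lower numbers stand for stronger inhibition and higher numbers for weaker inhibition:
Compound 1 `Cc1nc(N)c2c(-c3ccco3)cn([C@@H]3O[C@H](CO)[C@@H](O)[C@H]3O)c2n1`: > 20000 nM, a limit
Compound 2 `Cc1nc(N)c2c(-c3ccccc3)cn([C@@H]3O[C@H](CO)[C@@H](O)[C@H]3O)c2n1`: > 20000 nM, a limit

Compound 2 has no number in this assay, only the limit > 20000 nM. All that the series shows so far is the limit of > 20000 nM in this assay, at which 2 of the 2 values shown sit. Compound 3 `Cc1nc(N)c2c(I)cn([C@@H]3O[C@H](CO)[C@@H](O)[C@H]3O)c2n1` keeps the shared core and changes one group: iodo in place of phenyl on an aromatic carbon. Going by the values given here, the one measured step that bears on this change is a step that the two limits leave unreadable from compound 1 to compound 2, which also exchanges the group on an aromatic carbon. Its size cannot be read, so it gives no measure for the new exchange. Among the compounds with values here, no step of definite size or direction can be expected from these data, and a further limit is the likeliest outcome for compound 3. The expected step is an at least 1.1-fold lower number from compound 2 to compound 3 (0.04 log units; that floor lies within the scatter). Compound 3 is estimated at 18000 nM, with an expected range from 4000 nM to 40000 nM.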

Compound 3, half-maximal inhibitory concentration: 3480 nM
The estimate for compound 3 lay 5.2-fold (0.71 log units) above the measured number; the whole stated range lies above it.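

In this assay, going by these compounds alone, the place on an aromatic carbon of the five-membered aromatic ring now yields the first readable number of the series, and it does so with iodo, a single iodine atom, instead of a ring. Iodo in place of phenyl gives an at least 5.7-fold lower number from compound 2 to compound 3 (0.75 log units; beyond the scatter), and iodo in place of furan-2-yl gives an at least 5.7-fold lower number from compound 1 to compound 3 (0.75 log units; beyond the scatter); both sizes are minimums, as each starting value is only a limit. The group at this place can therefore change the read-out beyond the scatter, although most of the series still sits at a limit: the limit of > 20000 nM in this assay, at which 2 of the 3 values shown sit.

Whether the drop belongs to iodine itself or simply to the loss of a ring stays open, since iodo is the only group without a ring shown here. As far as these compounds go, how bromo, chloro, an amine or a short alkyl chain would read at this place also remains open.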